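Hydroxy for Methyl on the Amide Chain: a Repeated Change

The compounds below may be only part of what the source reports. "The series", "measured", "known", "first", "only" and "open" are said of these compounds alone.

Compound 1, `CC(O)C(=O)Nc1cc(Oc2ccc(Nc3nccc4[nH]cc(-c5ccc(F)cc5)c(=O)c34)cc2F)ccn1`: 47.8%
Compound 2, `CC(C)C(=O)Nc1cc(Oc2ccc(Nc3nccc4[nH]cc(-c5ccc(F)cc5)c(=O)c34)cc2F)ccn1`: 83.4%
Compound 3, `CC(C)(C)C(=O)Nc1cc(Oc2ccc(Nc3nccc4[nH]cc(-c5ccc(F)cc5)c(=O)c34)cc2F)ccn1`: -45.8%

Three compounds were tested in a functional assay on HT-29 cells (Homo sapiens) for antiproliferative activity, read by MTT assay, with a stated time of 72 h, tested at 10 uM; a higher number here means more inhibition at the concentration tested (going by the name of the read-out), a lower number less inhibition. The change hydroxy in place of methyl on a saturated chain carbon bound to a carbonyl carbon and a saturated chain carbon gave the step of a number 35.6 percentage points lower from compound 2 to compound 1 (beyond the scatter). Compound 3 stands lowest of the three, with the step of a number 93.6 percentage points lower from compound 1 to compound 3 (beyond the scatter) separating it from compound 1.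

The cores of compound 2 and compound 3 differ by methyl in place of hydrogen on a saturated chain carbon bound to a carbonyl carbon and two saturated chain carbons, which gave the step of a number 129.2 percentage points lower from compound 2 to compound 3 (beyond the scatter). Compound 4, `CC(C)(O)C(=O)Nc1cc(Oc2ccc(Nc3nccc4[nH]cc(-c5ccc(F)cc5)c(=O)c34)cc2F)ccn1`, carries the change hydroxy in place of methyl on a saturated chain carbon bound to a carbonyl carbon and two saturated chain carbons on the core of compound 3. Its place differs from the earlier one: there the carbon was bound to a carbonyl carbon and one saturated chain carbon, here to a carbonyl carbon and two saturated chain carbons, so this is the same kind of change, not the same change.

For the measured compounds named here, compound 4 is expected to show a step of a number 30.8 percentage points higher from compound 3 to compound 4 (beyond the scatter) in this assay, smaller than the earlier one and of uncertain sign, because compound 3 already gives -45.8% and the only precedent is a number 35.6 percentage points lower from compound 2 to compound 1 (beyond the scatter). Compound 4 is thus estimated at -15%, between -60% and 40%.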

Compound 4, a percentage reported as inhibition, at one concentration (the size of the read-out at that concentration, not a potency): -2.9%
Compound 4: middle estimate off by 12.1 percentage points, on the low side, within the range that was stated.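

On the core of compound 3, hydroxy in place of methyl gave the step of a number 42.9 percentage points higher from compound 3 to compound 4 (beyond the scatter), so in this assay the change did not keep the direction it had on the other core: the same change on two cores in this assay, a number 35.6 percentage points lower (beyond the scatter) from compound 2 to compound 1 and a number 42.9 percentage points higher (beyond the scatter) from compound 3 to compound 4, 78.5 percentage points apart, beyond the scatter of two such steps

Methyl in place of hydrogen also depended on the core, giving the step of a number 50.7 percentage points lower from compound 1 to compound 4 (beyond the scatter), much smaller than the step it had on the other core: the same change on two cores in this assay, a number 129.2 percentage points lower (beyond the scatter) from compound 2 to compound 3 and a number 50.7 percentage points lower (beyond the scatter) from compound 1 to compound 4, 78.5 percentage points apart, beyond the scatter of two such steps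

Hydroxy in place of hydrogen gave the step of a number 86.3 percentage points lower from compound 2 to compound 4 (beyond the scatter), but these few steps, read at a single concentration, show only that neither change can be carried over as a fixed step in this series, and they do not show why the sign reverses or how the change would run on any further core.

The compounds shown leave open whether an amine or a carboxylic acid in place of the hydroxy would follow compound 2 or compound 4. They also leave open what a longer chain on the amide carbonyl would do in this assay.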